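From a Dimethylamino Chain to a Diisopropylamino Chain

The compounds below may be only part of what the source reports. "The series", "measured", "known", "first", "only" and "open" are said of these compounds alone.

The measured compounds:
compound 1, `Cc1cc(C)nc(N(CCN(C)C)C(=O)N(C)C)c1` — 58%
compound 2, `Cc1cccc(N(CCN(C(C)C)C(C)C)C(=O)N(C)C)n1` — 87%

In a functional assay on the whole organism (stomach) for inhibition, with Canis familiaris (Canis lupus familiaris) as the target, at a dose of 20 mg/kg by the oral route (a lower number here means a weaker effect, a higher number a stronger effect of the compound at the dose given), compound 1 gives 58%, the lower of the two numbers. Compound 2 gives 87%, a gap beyond the usual scatter, though the two compounds differ in more than one place, so the two values show only that much. Compound 3, `Cc1cc(C)nc(N(CCCN(C(C)C)C(C)C)C(=O)N(C)C)c1`, has not yet been measured. It differs from compound 1 by (diisopropylamino)methyl in place of dimethylamino on a saturated chain carbon, two bonds along the chain from an amide-type nitrogen. Among the measured compounds shown here, compound 2 bears the same kind of amine at the end of its chain and gives 87%, so an upward step from compound 1 is expected rather than none, although the chain of compound 3 is longer and no measured pair isolates that. The expected step is a number 17 percentage points higher from compound 1 to compound 3 (beyond the scatter). Compound 3 is estimated at 75%, with a range from 55% to 92%.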

Compound 3, a percentage reported as inhibition, in the whole organism at one dose (the size of the read-out at that dose, not a potency): 0%
Estimate against measurement, compound 3: 75 percentage points above; measured number outside the range, below it.
By their numbers in this assay, from the lowest: compound 3; then compound 1; then compound 2.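

In this assay, among the compounds shown here, the single change at this position, (diisopropylamino)methyl in place of dimethylamino on a saturated chain carbon, two bonds along the chain from an amide-type nitrogen, comes with a number 58 percentage points lower from compound 1 to compound 3 (beyond the scatter) and shows that the position is far from indifferent to what it carries. Compound 3 gives 0% at the dose given, so this one exchange is enough to remove the whole of the effect that compound 1 shows on the same core. Nothing available accounts for this loss.

From the compounds shown here alone, the change lengthens the chain and alters the groups on the amine in a single step, so it remains open which of the two goes with the loss. A (dimethylamino)methyl group or a diisopropylamino group at this position would separate the two.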